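A few compounds are considered here, and "the series" means these few. Any claim that something is new, unique, unknown or untested is made for them only; others in the source may bear on it.

Compound 1 `Cc1ccc(C(c2ccn(-c3ccc(Cl)cc3)c2)n2ccnc2)cc1` gives 42600 nM
Compound 2 `Fc1ccc(-n2ccc(C(c3ccccc3)n3ccnc3)c2)cc1` gives 104000 nM
Compound 3 `Cc1ccc(C(c2ccn(-c3ccc(F)cc3)c2)n2ccnc2)cc1` gives 60700 nM

In an ADME assay on L6 cells (Rattus norvegicus) for cytotoxicity, read by fluorescence and resazurin assay, with a stated time of 72 h (a lower number here means that less compound is tolerated, a higher number that more compound is tolerated), compound 3 lies within the scatter of both compound 1 and compound 2. Compound 4 `Fc1ccc(-n2ccc(C(c3ccc(Cl)cc3)n3ccnc3)c2)cc1` is still unmeasured. It carries chloro in place of methyl on an aromatic carbon and so turns 4-methylphenyl into 4-chlorophenyl. Among the compounds with values here, no measured step makes this exact swap, but two bear on it. Methyl in place of hydrogen gave a 1.7-fold lower number from compound 2 to compound 3 (0.23 log units; within the scatter) and fluoro in place of chloro gave a 1.4-fold higher number from compound 1 to compound 3 (0.15 log units; within the scatter) in the same read-out. Both are small, so no change beyond the scatter is expected. The expected step is a 1.2-fold lower number from compound 3 to compound 4 (0.07 log units; within the scatter) and stays within it. Compound 4 is estimated at 52000 nM, with an expected range from 26000 nM to 100000 nM.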

Compound 4, half-maximal cytotoxic concentration: 47500 nM
Compound 4: middle estimate off by 1.1-fold (0.04 log units), on the high side, and the stated range covers the measured number.
By their numbers in this assay, from the lowest: compounds 1, 4, 3 and 2 (each within the scatter of the next, the first and the last beyond it).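

Chloro in place of methyl, para to a large group, gives a 1.3-fold lower number from compound 3 to compound 4 (0.11 log units; within the scatter), so this assay does not separate these two groups at this position. Chloro in place of hydrogen at the same position gives a 2.2-fold lower number from compound 2 to compound 4 (0.34 log units; beyond the scatter), a modest step and the first single change here to pass the scatter, while methyl in place of hydrogen gave a 1.7-fold lower number from compound 2 to compound 3 (0.23 log units; within the scatter). Nothing measured here offers an explanation for this. The compounds shown leave open whether an amine or a carboxylic acid at this position would move the number further. They also leave open how chloro would behave at another place on this ring.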